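The compounds below may be only part of what the source reports. "The series", "measured", "known", "first", "only" and "open" are said of these compounds alone.

Measured in a functional assay on A2780 cells (Homo sapiens) for cytotoxicity, read by sulforhodamine B assay, with a stated time of 72 h; on this read-out higher numbers stand for weaker inhibition and lower numbers for stronger inhibition:
- Compound 1 `O=C(NCc1ccc(S(=O)(=O)c2ccccc2)cc1)N1Cc2cccnc2C1`: > 2000 nM, a limit.
- Compound 2 `O=C(NCc1ccc(S(=O)(=O)c2ccccc2)cc1)N1CCc2ccncc2C1`: > 2000 nM, a limit.
- Compound 3 `CC(C)n1cc(S(=O)(=O)c2ccc(CNC(=O)N3Cc4ccncc4C3)cc2)cn1`: 11 nM.

Going by the values given here, compound 3 gives the only number in this set, 11 nM. The other two results are limits. Compound 4 `O=C(NCc1ccc(S(=O)(=O)C2CCN(C3COC3)CC2)cc1)N1Cc2ccncc2C1` carries 1-(oxetan-3-yl)piperidin-4-yl in place of 1-isopropyl-1H-pyrazol-4-yl on a sulfonyl sulfur. Among the compounds with values here, no measured pair isolates this change, so the expectation starts from compound 3 at 11 nM and remains loose. A modest move toward weaker inhibition in this assay is expected, with the estimated step being a 2.3-fold higher number from compound 3 to compound 4 (0.36 log units; beyond the scatter). The estimated value for compound 4 is 25 nM, within a range of 6 nM to 120 nM.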

Compound 4, half-maximal inhibitory concentration: 7.4 nM
Compound 4: middle estimate off by 3.4-fold (0.53 log units), on the high side, within the range that was stated.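

At this place, on a sulfonyl sulfur, an aromatic five-membered ring and a non-aromatic pair of rings give results within the scatter of each other in this assay, with a 1.5-fold lower number from compound 3 to compound 4 (0.17 log units; within the scatter). For compound 3 and compound 4, an aromatic ring on the sulfonyl sulfur is therefore not required to keep this level of inhibition.

As far as these compounds go, it remains open how a piperidin-4-yl carrying a free amine or a methyl on its nitrogen would compare with compound 4. No step to compound 1 or compound 2 can be read, as both results are limits: the limit of > 2000 nM in this assay, at which 2 of the 4 values shown sit.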